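Benzoyl replaced on an oxygen: expectation for compound 4

A few compounds are considered here, and "the series" means these few. Any claim that something is new, unique, unknown or untested is made for them only; others in the source may bear on it.

In a functional assay on HCT-116 cells (Homo sapiens) for antiproliferative activity, read by MTT assay, with a stated time of 48 h (on this read-out higher numbers stand for weaker inhibition and lower numbers for stronger inhibition), compound 1 `CCCCCCCC(CCO)n1cnc2c(Cl)nc(F)nc21` gives 17600 nM, compound 2 `CCCCCCCCCC(CCO)n1cnc2c(Cl)nc(F)nc21` gives 32100 nM and compound 3 `O=C(OCC(CCO)n1cnc2c(Cl)nc(F)nc21)c1ccccc1` gives 5170 nM. Compound 3 thus holds the lowest of the three numbers, beyond the scatter from each of the other two.

Compound 4 `CC(C)(C)[Si](C)(C)OCC(CCO)n1cnc2c(Cl)nc(F)nc21` has not yet been measured. The change from compound 3 is a group of 7 heavy atoms (6 carbon, 1 silicon; no ring) in place of a group of 8 heavy atoms (7 carbon, 1 oxygen; one six-membered aromatic ring of carbon only), on an oxygen on a saturated carbon. The new group therefore carries no ring, and it sits on an oxygen on a saturated carbon.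

For the measured compounds named here, only one measured step exists, a 1.8-fold higher number from compound 1 to compound 2 (0.26 log units; within the scatter). Going by the values given here, it lies within the scatter and concerns a saturated chain, not this oxygen, so no measured step covers the change directly. Among the compounds with values here, the only indirect guide is a comparison of values. Compound 1 at 17600 nM and compound 2 at 32100 nM also lack a ring in that part of the structure, and both stand above compound 3 at 5170 nM. This rests on a single ring-bearing compound, so the guide is weak.

A moderate rise is expected, with the estimated step being a 2.1-fold higher number from compound 3 to compound 4 (0.33 log units; beyond the scatter). For compound 4 the estimated value is 11000 nM, with an expected range of 4000 nM to 30000 nM.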

Compound 4, half-maximal inhibitory concentration: 7780 nM
For compound 4 the middle estimate is 1.4-fold (0.15 log units) above the measured one, within the range that was stated.
By their numbers in this assay, from the lowest: compounds 3 and 4 (each within the scatter of the next); then compounds 1 and 2 (each within the scatter of the next).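

In this assay the exchange of benzoyl for the group of 7 heavy atoms (6 carbon, 1 silicon; no ring) on this oxygen gives a 1.5-fold higher number from compound 3 to compound 4 (0.18 log units; within the scatter) and so a six-membered aromatic ring, a carbonyl double bond and a hydrogen-bond acceptor in this group are not required for a number in this range. The lack of a ring therefore does not by itself place a compound with compounds 1 and 2: a 4.1-fold lower number from compound 2 to compound 4 (0.62 log units; beyond the scatter) and a 2.3-fold lower number from compound 1 to compound 4 (0.35 log units; beyond the scatter) are both read for the group of 8 heavy atoms (6 carbon, 1 oxygen, 1 silicon; no ring) in place of all-carbon groups on the saturated chain carbon, two bonds along the chain from an aromatic nitrogen. Nothing available explains these differences in terms of mechanism.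

The free hydroxyl at this place, or a benzyl or acetyl group on this oxygen, would be needed to tell whether this oxygen requires a substituent at all and to separate the ring from the carbonyl. As far as these compounds go, how far the group on this oxygen can grow, for example with a longer chain, also stays open.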